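A few compounds are considered here, and "the series" means these few. Any claim that something is new, unique, unknown or untested is made for them only; others in the source may bear on it.

Working notes on the series with the shared core, read in an ADME assay on HepG2 cells (Homo sapiens) for cytotoxicity, read by luminescence, CellTiter-Glo and ATP content, with a stated time of 72 h; a higher number here means that more compound is needed for the effect, a lower number that less compound is needed. Compound 1 `Cc1cc(C)cc(Cc2ccc3c(NCCCNCc4ccco4)ccnc3c2)c1` gives 6270 nM, compound 2 `c1ccc(-c2ccc3c(NCCCNCc4ccco4)ccnc3c2)cc1` gives 5920 nM, and compound 3 `COc1ccc(Oc2ccc3c(NCCCNCc4ccco4)ccnc3c2)cc1` gives 5300 nM, so compound 3 stands level with both others within the scatter. Next is compound 4 `c1coc(CNCCCNc2ccnc3cc(C4CCCCC4)ccc23)c1`, with cyclohexyl in place of 4-methoxyphenoxy on an aromatic carbon. Three measured steps at this same place bear on it: a 1.1-fold lower number from compound 1 to compound 2 (0.02 log units; within the scatter), a 1.2-fold lower number from compound 1 to compound 3 (0.07 log units; within the scatter) and a 1.1-fold lower number from compound 2 to compound 3 (0.05 log units; within the scatter), all within the scatter. Among the compounds with values here, none of the measured compounds carries a non-aromatic ring there, so the range stays wide. No step beyond the scatter is expected in this assay, and neither direction is favoured. The expected step is a 1.0-fold higher number from compound 3 to compound 4 (0.02 log units; within the scatter). For compound 4 the estimated value is 5500 nM, with an expected range of 2800 nM to 10500 nM.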

Compound 4, half-maximal effective concentration: 4760 nM
The estimate for compound 4 lay 1.2-fold (0.06 log units) above the measured number; low and high end bracket the measured number.
By their numbers in this assay, from the lowest: compounds 4, 3, 2 and 1 (each within the scatter of the next).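

In this assay, a non-aromatic ring of carbon only at this aromatic carbon stays within the scatter of all three earlier groups, with (a 1.1-fold lower number from compound 3 to compound 4 (0.05 log units; within the scatter)), (a 1.2-fold lower number from compound 2 to compound 4 (0.09 log units; within the scatter)) and (a 1.3-fold lower number from compound 1 to compound 4 (0.12 log units; within the scatter)). Replacing 4-methoxyphenoxy with cyclohexyl removes the aromatic ring and both oxygens, and still no step beyond the scatter appears. No available evidence accounts for this flat reading.

Going by these compounds, whether an amine or a carboxylic acid on this carbon would stay within the same scatter remains open. So does the effect of any change elsewhere on the shared core.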